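Shortening a Side Chain: Compound 1 to Compound 4

This account rests on a few compounds, and the source may have more. Where it says the series, first, only, none or still open, it means among the compounds named here.

Of the compounds shown here, three have so far been measured in a functional assay on HepG2 cells (Homo sapiens) for antiproliferative activity, read by CCK-8 assay, with a stated time of 72 h, tested at 8 uM; on this read-out higher numbers stand for a stronger effect at the one concentration tested and lower numbers for a weaker effect. Compound 1 `CCCCn1cnc2c(NCc3ccc(C(=O)Nc4ccccc4N)cc3)nc(Cl)nc21` gives 19.6%, the lowest of the three numbers. Compound 2 `CN1CCN(c2nc(Cl)nc3c2ncn3Cc2ccc(C(=O)Nc3ccccc3N)cc2)CC1` gives 75% and compound 3 `Nc1ccccc1NC(=O)c1ccc(COCNc2nc(Nc3cccc(Cl)c3)c3ncn(C4CCCC4)c3n2)cc1` gives 63.2%; both stand beyond the usual scatter above compound 1, and compound 3 is the nearer of the two. No pair among these three differs in only one place, so the measured numbers give no direct reading of what one small change does to this read-out.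

Compound 4 `CCCn1cnc2c(NCc3ccc(C(=O)Nc4ccccc4N)cc3)nc(Cl)nc21` has not yet been measured. It differs from compound 1 in one place: hydrogen in place of methyl on a saturated chain carbon, three bonds along the chain from an aromatic nitrogen. Everything else in the molecule stays the same.

Without a single-change step among the measured compounds, the expectation rests on the size of the change alone, which is one heavy atom removed from a saturated chain. The step from compound 1 to compound 4 is expected to be a number 0.4 percentage points higher from compound 1 to compound 4 (within the scatter), that is, no change beyond the scatter in either direction. Compound 4 is therefore estimated at 20%, with a range from 8% to 35%.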

Compound 4, a percentage reported as inhibition, at one concentration (the size of the read-out at that concentration, not a potency): 14.1%
The estimate for compound 4 lay 5.9 percentage points above the measured number, within the range that was stated.
By their numbers in this assay, from the lowest: compounds 4 and 1 (each within the scatter of the next); then compound 3; then compound 2.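

Cutting the butyl chain to propyl gives the first change in a single place among these compounds, and in this assay the step of a number 5.5 percentage points lower from compound 1 to compound 4 (within the scatter) is small enough to sit inside the normal variation of the read-out. At this saturated chain carbon, three bonds along the chain from an aromatic nitrogen, removing one methyl therefore leaves the number without a change that can be told from scatter, so this one carbon at the end of the chain shows no measurable role on this read-out. No separate measurement bears on why the two compounds read alike.

The compounds shown compare only butyl and propyl at this place, which leaves open what a shorter ethyl chain or a longer pentyl chain would do. They also leave open whether a chain ending in an amine or a carboxylic acid would give a number beyond the scatter, which would show whether this position can affect the read-out at all.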